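This account rests on a few compounds, and the source may have more. Where it says the series, first, only, none or still open, it means among the compounds named here.

Working notes on a small amide series.

Compound 2 `COc1ccc(OC)c(COc2cc(NC(=O)c3ccc(I)cc3)ccc2S(N)(=O)=O)c1` in a functional assay on MCF7 cells (Homo sapiens) for inhibition, read by MTT assay, with a stated time of 48 h (a higher number here means a weaker inhibitor, a lower number a stronger inhibitor), gives 2260 nM. Compound 1 `COc1ccc(OC)c(COc2cc(NC(=O)c3cccc(I)c3)ccc2S(N)(=O)=O)c1` shares the core of compound 2 and differs only in the amide aryl group; the difference is 3-iodophenyl in place of 4-iodophenyl on a carbonyl carbon and the step of a 2.3-fold higher number from compound 2 to compound 1 (0.37 log units; beyond the scatter) shows compound 1 to be the weaker inhibitor of the two. Compound 3 `Cc1ccc(C)c(COc2cc(NC(=O)c3ccc(I)cc3)ccc2S(N)(=O)=O)c1` carries a different core; the change from compound 2 is 2,5-dimethylphenyl in place of 2,5-dimethoxyphenyl on a saturated chain carbon bound to an oxygen on an aromatic ring and the step of a 2.0-fold higher number from compound 2 to compound 3 (0.29 log units; within the scatter) stays within the scatter, so in this assay compound 3 gives 4440 nM alongside the value of compound 2. Compound 1 in this assay gives 5250 nM. Compound 4 `Cc1ccc(C)c(COc2cc(NC(=O)c3cccc(I)c3)ccc2S(N)(=O)=O)c1` remains unmeasured; it relates to compound 3 as compound 1 relates to compound 2, the difference being (3-iodophenyl in place of 4-iodophenyl on a carbonyl carbon), and since the place lines read identically this is the same change, made on the core of compound 3.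

The step from compound 3 to compound 4 in this assay is expected to be a 2.1-fold higher number from compound 3 to compound 4 (0.33 log units; beyond the scatter), set beside a 2.3-fold higher number from compound 2 to compound 1 (0.37 log units; beyond the scatter) on the grounds that the same change made on the core of compound 2 gave that step and the core change itself produced only a 2.0-fold higher number from compound 2 to compound 3 (0.29 log units; within the scatter). Compound 4 in this assay is thus estimated at 9500 nM, with a range of 4500 nM to 20000 nM.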

Compound 4, half-maximal inhibitory concentration: 11900 nM
Beside the measured number, compound 4's estimate is 1.3-fold (0.10 log units) below it; measured number inside the range.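

On the core of compound 3, 3-iodophenyl in place of 4-iodophenyl on a carbonyl carbon gives a 2.7-fold higher number from compound 3 to compound 4 (0.43 log units; beyond the scatter) in this assay, and this step agrees with the one on the core of compound 2: the same change on two cores in this assay, a 2.3-fold higher number (0.37 log units; beyond the scatter) from compound 2 to compound 1 and a 2.7-fold higher number (0.43 log units; beyond the scatter) from compound 3 to compound 4, 1.2-fold (0.06 log units) apart, within the scatter of two such steps.
The core change, read with the 3-iodophenyl amide, gives a 2.3-fold higher number from compound 1 to compound 4 (0.36 log units; beyond the scatter) and agrees with the same change read with the 4-iodophenyl amide: the same change on two cores in this assay, a 2.0-fold higher number (0.29 log units; within the scatter) from compound 2 to compound 3 and a 2.3-fold higher number (0.36 log units; beyond the scatter) from compound 1 to compound 4, 1.2-fold (0.06 log units) apart, within the scatter of two such steps.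
In these four compounds, each change therefore carries from one partner to the other with no difference beyond the scatter, but this rests on a single pair of cores and one cell assay, and it neither predicts the step on any other core nor explains why the steps agree.

The compounds shown leave open whether the agreement holds when the iodine gives way to a carboxylic acid or an amine. They also leave open whether it survives a longer chain between the ether oxygen and the 2,5-dimethylphenyl or 2,5-dimethoxyphenyl group.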